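The source may report more compounds than this note shows. Statements on the series, on what has been measured and on what is new or still open speak of the compounds shown alone.

Measured so far:
compound 1 `COc1ccc(-c2ncc(C(=O)O)c(=O)[nH]2)cc1` — > 5 mg/kg
compound 2 `CCOC(=O)c1cnc(-c2ccccc2F)[nH]c1=O` — > 10 mg/kg

In a functional assay on the whole organism (strain Sprague-Dawley) for inhibition, with Rattus norvegicus as the target, with a stated time of 10 min (a higher number here means that more compound is needed for the effect, a lower number that less compound is needed), compound 2 gives only a limit of the assay, > 10 mg/kg (the limit of > 10 mg/kg in this assay, at which 1 of the 2 values shown sits). Compound 1 likewise gives only a limit, > 5 mg/kg (the limit of > 5 mg/kg in this assay, at which 1 of the 2 values shown sits). Compound 3 `CCCCCOc1ccccc1-c1ncc(C(=O)OCC)c(=O)[nH]1` is not yet measured; it differs from compound 2 by pentyloxy in place of fluoro on an aromatic carbon. Among the measured compounds shown here, no measured step between two compounds is available here, and both known values are limits, so the direction of the change is open. The expected step is a number no higher from compound 2 to compound 3 (the limit leaves the size open), which would stay within the usual scatter. Compound 3 is therefore estimated at 10 mg/kg, expected to fall between 3 mg/kg and 30 mg/kg.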

Compound 3, dose for 50% inhibition: 2 mg/kg
The estimate for compound 3 lay 5.0-fold (0.70 log units) above the measured number; the measured number lies below the stated range.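

In this assay, pentyloxy in place of fluoro on this aromatic carbon, ortho to a large group, gives an at least 5.0-fold lower number from compound 2 to compound 3 (0.69 log units; beyond the scatter). Going by these compounds, compound 2 gives only a limit of the assay, so the true size of this step is unknown: the limit of > 10 mg/kg in this assay, at which 1 of the 3 values shown sits. The change shows that this position accepts a much larger group than fluoro, and that less compound is then needed for the effect.

On these data alone, whether the oxygen or the length of the chain matters remains open. An ethoxy group, a hexyl chain or an amine at this position would help to separate these possibilities.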